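A few compounds are considered here, and "the series" means these few. Any claim that something is new, unique, unknown or untested is made for them only; others in the source may bear on it.

Of the compounds shown here, two of a shared core have been measured so far. Compound 1, `O=C1C(=Cc2ccc(F)cc2)C(=O)N(c2ccc(Cl)cc2)N1c1ccc(Cl)cc1`, carries a 4-fluorophenyl on a double-bonded chain carbon bound to a double-bonded ring carbon. In a functional assay on MCF7 cells (Homo sapiens) for cytotoxicity, read by MTT assay, with a stated time of 72 h (on this read-out higher numbers stand for weaker inhibition and lower numbers for stronger inhibition), compound 1 gives 31400 nM. Compound 2, `COc1cccc(C=C2C(=O)N(c3ccc(Cl)cc3)N(c3ccc(Cl)cc3)C2=O)c1`, carries a 3-methoxyphenyl at that place, and in this assay compound 2 gives 18100 nM. Within the data shown here, the step of a 1.7-fold lower number from compound 1 to compound 2 (0.24 log units; within the scatter) is the only measured step, and it is within the scatter. Compound 1 therefore stands at the highest of the two numbers, with compound 2 as its nearest neighbour, though the two cannot be ranked against each other.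

Compound 3, `O=C1C(=Cc2ccco2)C(=O)N(c2ccc(Cl)cc2)N1c1ccc(Cl)cc1`, is not yet measured. It differs from compound 1 as follows: furan-2-yl in place of 4-fluorophenyl on a double-bonded chain carbon bound to a double-bonded ring carbon. No measured step replaces an aryl group on that carbon with a five-membered aromatic ring, so the expectation rests on the one step shown, which was within the scatter. The step from compound 1 to compound 3 is therefore expected to be small, a 1.3-fold lower number from compound 1 to compound 3 (0.10 log units; within the scatter), in either direction. Compound 3 is estimated to give 25000 nM in this assay, with a range from 8000 nM to 80000 nM.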

Compound 3, half-maximal inhibitory concentration: 20300 nM
Compound 3: the middle estimate sits 1.2-fold (0.09 log units) above what was measured; the measured number falls inside the stated range.
By their numbers in this assay, from the lowest: compounds 2, 3 and 1 (each within the scatter of the next).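

In this assay, the place on a double-bonded chain carbon bound to a double-bonded ring carbon now also holds a five-membered aromatic ring with 1 hetero atom, and not only a six-membered aromatic ring of carbon only. Putting furan-2-yl in place of 4-fluorophenyl gives a 1.5-fold lower number from compound 1 to compound 3 (0.19 log units; within the scatter), and putting it in place of 3-methoxyphenyl gives a 1.1-fold higher number from compound 2 to compound 3 (0.05 log units; within the scatter), so even this change of ring leaves all three compounds unranked against one another. No separate measurement bears on these results, so the numbers can only be described here, not explained.

What the compounds shown leave open is whether any group at this place can produce a step beyond the scatter, since all three carry an aromatic ring there and none carries, for example, an amine, a carboxylic acid or a longer saturated carbon chain. The rest of the shared core is also the same in all three compounds, so they show nothing about how changes elsewhere would affect the number.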